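Bromo at a second position on the shared core of compound 1

The compounds below may be only part of what the source reports. "The series", "measured", "known", "first", "only" and "open" are said of these compounds alone.

Among the compounds with values here, in an ADME assay on KB cells (Homo sapiens) for cytotoxicity, read by resazurin assay, with a stated time of 72 h (on this read-out higher numbers stand for weaker inhibition and lower numbers for stronger inhibition), compound 1 `O=C(/C=C/c1cccnc1)c1ccccc1` gives 7700 nM; the only other number measured is that of compound 2 `O=C(/C=C/c1cccnc1)c1ccc(Br)cc1`, which in this assay gives 7900 nM, and the step of a 1.0-fold higher number from compound 1 to compound 2 (0.01 log units; within the scatter) shows the two standing together within the scatter. Compound 3 `O=C(/C=C/c1cccnc1)c1ccccc1Br` differs from compound 1 by bromo in place of hydrogen on an aromatic carbon. Within the data shown here, the one step that bears on this change is the same group entering elsewhere, and it was a 1.0-fold higher number from compound 1 to compound 2 (0.01 log units; within the scatter); a step of a 1.0-fold higher number from compound 1 to compound 3 (0.02 log units; within the scatter) is therefore expected, none beyond the scatter. Compound 3 is estimated at 8000 nM in this assay, within 4000 nM to 16000 nM.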

Compound 3, half-maximal inhibitory concentration: > 300000 nM
Compound 3 ended at the assay's limit; the forecaster's own chance of this, stated with the estimate: 5%; middle value at least 37-fold (1.57 log units) from the limit.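

In this assay, bromo on the aromatic carbon ortho to a large group gives an at least 38-fold higher number from compound 1 to compound 3 (1.59 log units; beyond the scatter), while the same group at the position in compound 2 gives a 1.0-fold higher number from compound 1 to compound 2 (0.01 log units; within the scatter). The outcome of this change therefore depends on where the bromo enters, which the earlier step alone did not show. The value of compound 3 is a limit and not a number: the limit of > 300000 nM in this assay, at which 1 of the 3 values shown sits.

From the compounds shown here alone, how far compound 3 lies past that limit stays open. Also open, going by these compounds, is whether fluoro, methyl or an amine on the same carbon would give a step of similar size, or whether this one belongs to bromo alone.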